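The compounds below may be only part of what the source reports. "The series", "measured", "known", "first", "only" and "open" are said of these compounds alone.

Measured compounds:
compound 1 `Nc1nc2cc(-c3nn(CCCCCC(=O)NO)c4ncnc(N)c34)ccc2o1` — 2030 nM
compound 2 `Nc1ncnc2c1c(-c1cnc3[nH]ccc3c1)nn2CCCCCCC(=O)NO` — 30800 nM
compound 3 `Nc1ncnc2c1c(-c1cnc3[nH]ccc3c1)nn2CCCCCC(=O)NO` — "not determined" (no result reported)

In a functional assay on Bel-7402 cells (Homo sapiens) for inhibition, read by MTT assay, with a stated time of 72 h (a higher number here means a weaker inhibitor, a lower number a stronger inhibitor), compound 2 gives 30800 nM, the higher of the two numbers; compound 1 gives 2030 nM, and the gap between them is beyond the scatter. Compound 4 `Nc1nc2cc(-c3nn(CCCCCCC(=O)NO)c4ncnc(N)c34)ccc2o1` has not been measured. It differs from compound 2 in one place: a group of 10 heavy atoms (7 carbon, 2 nitrogen, 1 oxygen; one five-membered aromatic ring with 2 hetero atoms, one six-membered aromatic ring of carbon only) in place of a group of 9 heavy atoms (7 carbon, 2 nitrogen; one five-membered aromatic ring with 1 hetero atom, one six-membered aromatic ring with 1 hetero atom), on an aromatic carbon. Within the data shown here, no pair of measured compounds shows the size of this exchange on its own. Compound 1 carries the same 2-amino-1,3-benzoxazol-5-yl group and gives 2030 nM, though it also differs from compound 4 in the chain. Compound 4 is therefore expected to give a lower number than compound 2, a step of a 7.7-fold lower number from compound 2 to compound 4 (0.89 log units; beyond the scatter) in this assay. The estimate for compound 4 is 4000 nM, ranging from 1000 nM to 20000 nM.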

Compound 4, half-maximal inhibitory concentration: > 50000 nM
Compound 4 gave a limit, no number (the forecaster's own chance of this, stated with the estimate: 5%); middle value at least 12-fold (1.09 log units) from the limit.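

In this assay the chain proves a sensitive place: with the 2-amino-1,3-benzoxazol-5-yl group held fixed, (hydroxycarbamoyl)methyl in place of hydroxycarbamoyl gives an at least 24-fold higher number from compound 1 to compound 4 (1.39 log units; beyond the scatter) on the saturated chain carbon. For compound 4 the entry > 50000 nM is a limit of the assay and not a number. On the longer chain, exchanging the other ring group for 2-amino-1,3-benzoxazol-5-yl gives an at least 1.6-fold higher number from compound 2 to compound 4 (0.21 log units; that floor lies within the scatter) and fixes no firm order between the two groups. Going by these compounds, whether a carboxylic acid in place of the hydroxycarbamoyl end, or a shorter chain, would restore inhibition stays open.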